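Trimming the Ether Chain of Compound 1

The source may hold more compounds than are shown below. What is called first, only, known or untested is meant among the compounds shown, and "the series" means these compounds.

Measured so far:
- compound 1, `COc1ccnc(Nc2ccc(Cl)c(OCC=C(C)C)c2)n1`: 9000 nM
- compound 2, `CC(C)=CCOc1cc(Nc2nccc(CO)n2)ccc1Cl`: 220 nM

For the measured compounds named here, in an ADME assay on MT2 cells (Homo sapiens) for cytotoxicity (a lower number here means that less compound is tolerated, a higher number that more compound is tolerated), compound 1 gives 9000 nM, the highest of the two numbers; the only neighbour is compound 2, which gives 220 nM. Going by the values given here, the one measured step, a 41-fold lower number from compound 1 to compound 2 (1.61 log units; beyond the scatter), changes the group on the core, not the side chain. Compound 3, `C/C=C/COc1cc(Nc2nccc(OC)n2)ccc1Cl`, differs from compound 1 in the side chain only: prop-1-en-1-yl in place of 2-methylprop-1-en-1-yl on a saturated chain carbon bound to an oxygen on an aromatic ring. Among the compounds with values here, no measured step touches this chain, so nothing here bears directly on the change. Within the data shown here, with no step to lean on, a small step is expected, no change at the digits printed from compound 1 to compound 3 (within the scatter), none beyond the scatter. Compound 3 is therefore estimated at 9000 nM, with a range from 3000 nM to 27000 nM.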

Compound 3, half-maximal cytotoxic concentration: 17000 nM
For compound 3 the middle estimate is 1.9-fold (0.28 log units) below the measured one; measured number inside the range.
By their numbers in this assay, from the lowest: compound 2; then compounds 1 and 3 (each within the scatter of the next).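

For the compounds shown here, this is the first measured change to the side chain rather than to the group on the core. In this assay, swapping 2-methylprop-1-en-1-yl for prop-1-en-1-yl gives a 1.9-fold higher number from compound 1 to compound 3 (0.28 log units; within the scatter), so compounds 1 and 3 cannot be told apart here and this position accepts the shorter chain without a change beyond the scatter. No supporting measurement is available to explain this result.

The compounds shown leave open whether the double bond in the chain matters, since a saturated butyl chain, a benzyl group or a longer chain could behave differently in the same place. They also leave open whether the same trimming would hold with hydroxymethyl on the core, as in compound 2.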